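Swapping the aryl group on the piperidine carbon

A few compounds are considered here, and "the series" means these few. Any claim that something is new, unique, unknown or untested is made for them only; others in the source may bear on it.

Compound 1 `CC1(c2ccccc2)CCCN(Cc2ccn3c(CC4CC4)nnc3c2C(F)(F)F)C1` gives 2.6 nM in an assay on CHO cells for positive allosteric modulation of metabotropic glutamate receptor 2 (Homo sapiens), read by scintillation counting, with a stated time of 30 min (a lower number here means that less compound is needed, a higher number that more compound is needed for the effect), while compound 2 `FC(F)(F)c1c(CN2CCC(c3ccccc3Cl)CC2)ccn2c(CC3CC3)nnc12` gives 13.5 nM in this assay, the higher of the two numbers shown. Compound 3 `Fc1ccc(C2CCN(Cc3ccn4c(CC5CC5)nnc4c3C(F)(F)F)CC2)c(F)c1` differs from compound 2 by 2,4-difluorophenyl in place of 2-chlorophenyl on a saturated ring carbon. Among the measured compounds shown here, no directly comparable pair of measured compounds exists for this exchange, so the change is not expected to move the number beyond the usual scatter in this assay. The estimated step from compound 2 to compound 3 is a 1.1-fold lower number from compound 2 to compound 3 (0.05 log units; within the scatter), and compound 3 is expected to give about 12 nM in this assay, within a range from 4 nM to 35 nM.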

Compound 3, half-maximal effective concentration: 15 nM
Beside the measured number, compound 3's estimate is 1.3-fold (0.10 log units) below it; the measured number falls inside the stated range.
By their numbers in this assay, from the lowest: compound 1; then compounds 2 and 3 (each within the scatter of the next).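

In this assay the exchange of 2-chlorophenyl for 2,4-difluorophenyl on this saturated ring carbon gives a 1.1-fold higher number from compound 2 to compound 3 (0.05 log units; within the scatter), so the two aryl groups cannot be told apart here. Thus a chlorine-bearing and a difluorinated phenyl ring serve equally at this position in this pair. No measurement bearing on this result is available. On these data alone, whether an unsubstituted phenyl, a pyridine or a methoxyphenyl would read the same at this carbon stays open. Compound 1 differs from compound 2 in more than one place, so no single change can be read from it.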